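Trimethoxyphenyl Swaps in an Antiproliferative Series

The source may hold more compounds than are shown below. What is called first, only, known or untested is meant among the compounds shown, and "the series" means these compounds.

Measured in a functional assay on A549 cells (Homo sapiens) for antiproliferative activity, read by MTT assay, with a stated time of 48 h; a lower number here means a stronger inhibitor, a higher number a weaker inhibitor:
compound 1, `COc1ccc(N/C=C\C(=O)c2cn(-c3ccccc3)nc2-c2ccc(OC)cc2)cc1`, gives 6780 nM
compound 2, `COc1ccc(-c2nn(-c3ccccc3)cc2C(=O)/C=C\Nc2cc(OC)c(OC)c(OC)c2)cc1`, gives 11200 nM
compound 3, `COc1ccc(N/C=C\C(=O)c2cn(-c3ccccc3)nc2-c2cc(OC)c(OC)c(OC)c2)cc1`, gives 4780 nM

Compound 1 and compound 3 lie within the scatter of each other, while compound 2 stands beyond the scatter from compound 3. Two single changes connect these compounds. From compound 1 to compound 2 the change is 3,4,5-trimethoxyphenyl in place of 4-methoxyphenyl on an amine nitrogen, and in this assay it gives a 1.7-fold higher number from compound 1 to compound 2 (0.22 log units; within the scatter). From compound 1 to compound 3 the change is 3,4,5-trimethoxyphenyl in place of 4-methoxyphenyl on an aromatic carbon, giving a 1.4-fold lower number from compound 1 to compound 3 (0.15 log units; within the scatter).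

Compound 4, `COc1cc(N/C=C\C(=O)c2cn(-c3ccccc3)nc2-c2cc(OC)c(OC)c(OC)c2)cc(OC)c1OC`, has not been measured. It differs from compound 3 by 3,4,5-trimethoxyphenyl in place of 4-methoxyphenyl on an amine nitrogen. This is the same change as that from compound 1 to compound 2, made on a different core; the two cores differ by 3,4,5-trimethoxyphenyl in place of 4-methoxyphenyl on an aromatic carbon. Resting on the step of a 1.7-fold higher number from compound 1 to compound 2 (0.22 log units; within the scatter), the step from compound 3 to compound 4 in this assay is expected to be a 1.7-fold higher number from compound 3 to compound 4 (0.23 log units; within the scatter). Compound 4 is therefore estimated at 8100 nM, with a likely range from 4000 nM to 16000 nM.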

Compound 4, half-maximal inhibitory concentration: 7980 nM
Estimate against measurement, compound 4: 1.0-fold (0.01 log units) above, and the stated range covers the measured number.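

On the amine nitrogen, 3,4,5-trimethoxyphenyl in place of 4-methoxyphenyl gives a 1.7-fold higher number from compound 3 to compound 4 (0.22 log units; within the scatter) in this assay, and this step carries over from one core to the other: the same change on two cores in this assay, a 1.7-fold higher number (0.22 log units; within the scatter) from compound 1 to compound 2 and a 1.7-fold higher number (0.22 log units; within the scatter) from compound 3 to compound 4, 1.0-fold (0.00 log units) apart, within the scatter of two such steps. On the aromatic carbon, the same swap gives a 1.4-fold lower number from compound 2 to compound 4 (0.15 log units; within the scatter), and it also carries over: the same change on two cores in this assay, a 1.4-fold lower number (0.15 log units; within the scatter) from compound 1 to compound 3 and a 1.4-fold lower number (0.15 log units; within the scatter) from compound 2 to compound 4, 1.0-fold (0.00 log units) apart, within the scatter of two such steps. Both comparisons rest on the same four compounds and each single step lies within the scatter, so the match shows that the two swaps combine consistently on these cores, but not that either swap on its own reliably changes activity or would behave the same way on any other core.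

The compounds shown leave open what smaller or different groups would do at these two places, such as a hydroxyl group or a fluorine in place of the methoxy groups. Also open, going by these compounds, is whether replacing the phenyl group shared by all four compounds with, for example, a benzyl group would change the picture.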